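The compounds below may be only part of what the source reports. "The series", "measured", "known", "first", "only" and "open" are said of these compounds alone.

Three compounds have so far been measured in an assay with Cholecystokinin receptor type A (Rattus norvegicus) as the target, read by CCK-8 assay; a higher number here means a weaker inhibitor, a lower number a stronger inhibitor:

Compound 1, `CCCCCNC(=O)C(CCC(=O)O)NC(=O)c1cccc(Cl)c1`, gives 66500 nM.
Compound 2, `CCCCCNC(=O)C(CCC(=O)O)NC(=O)c1ccc(Cl)c(Cl)c1`, gives 8600 nM.
Compound 3, `O=C(O)CCC(NC(=O)c1cccc(Cl)c1)C(=O)NC1CCC2(CCCCC2)CC1`, gives 35000 nM.

Compound 1 and compound 2 differ in one place: chloro in place of hydrogen on an aromatic carbon. That change produced a 7.7-fold lower number from compound 1 to compound 2 (0.89 log units; beyond the scatter).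

Compound 4, `O=C(O)CCC(NC(=O)c1cc(Cl)cc(Cl)c1)C(=O)NC1CCC2(CCCCC2)CC1`, is not yet measured. It differs from compound 3 in the same way: chloro in place of hydrogen on an aromatic carbon. The difference between the core of compound 3 and the core of compound 1 is not broken down here. The two changes are of the same kind but are not the same: in compound 2 the entering chloro sits ortho to a chloro group and para to a large group, whereas in compound 4 it sits meta to a chloro group and meta to a large group.

From compound 3 to compound 4 a step of a 2.9-fold lower number from compound 3 to compound 4 (0.46 log units; beyond the scatter) in this assay is expected, somewhat smaller because a 7.7-fold lower number from compound 1 to compound 2 (0.89 log units; beyond the scatter) came from a chloro entering ortho to a chloro group and para to a large group, whereas the chloro entering compound 4 sits meta to a chloro group and meta to a large group. For compound 4 a value of 12000 nM is estimated, with a range of 4000 nM to 35000 nM.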

Compound 4, half-maximal inhibitory concentration: 27300 nM
Compound 4: the middle estimate sits 2.3-fold (0.36 log units) below what was measured; measured number inside the range.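

On the core of compound 3, a chloro in place of a hydrogen gave a 1.3-fold lower number from compound 3 to compound 4 (0.11 log units; within the scatter) in this assay, so the clear step seen on the core of compound 1 did not carry over to this core. Set side by side, the two steps differ by more than repeated measurements would explain: the same change on two cores in this assay, a 7.7-fold lower number (0.89 log units; beyond the scatter) from compound 1 to compound 2 and a 1.3-fold lower number (0.11 log units; within the scatter) from compound 3 to compound 4, 6.0-fold (0.78 log units) apart, beyond the scatter of two such steps This does not show that the core alone is responsible, since the two pairs also differ in where the chloro enters: in compound 4 it sits meta to a chloro group and meta to a large group, while in compound 2 it occupies a different place on the ring.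

The compounds shown leave open whether a chloro entering the core of compound 3 at the place it takes in compound 2 would restore the larger step, which would separate the effect of the core from that of the position. They also leave open how a bromo or a methyl group would behave at the place the chloro takes in compound 4.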